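The source may report more compounds than this note shows. Statements on the series, on what has been measured and on what is new or still open speak of the compounds shown alone.

Measured compounds:
Compound 1 `COc1c(/C=C2/C(=O)Nc3ccccc32)c2ccccc2n1-c1ccccc1` gives 520 nM in a functional assay on cells (Leukemia cell, Homo sapiens) for cytotoxicity, with a stated time of 48 h; on this read-out higher numbers stand for weaker inhibition of growth and lower numbers for stronger inhibition of growth.
Compound 2 `O=C1Nc2ccccc2/C1=C\c1c(Cl)n(CCCc2ccccc2)c2ccccc12` gives 8910 nM in this assay.
Compound 3 `COc1c(/C=C2/C(=O)Nc3ccc(Cl)cc32)c2ccccc2n1-c1ccccc1` gives 2340 nM in this assay.

Of the compounds shown here, three built on two related cores have been measured so far. Compound 1 and compound 3 share one core and differ by a single change: chloro in place of hydrogen on an aromatic carbon. This change produced a 4.5-fold higher number from compound 1 to compound 3 (0.65 log units; beyond the scatter), so the chlorinated compound 3 inhibits growth less strongly than compound 1. Compound 2 carries the other core; how its core differs from that of compound 1 is not broken down here. In this assay compound 2 gives the highest of the three numbers, standing beyond the scatter from both compound 3 and compound 1.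

The unmeasured compound 4 `O=C1Nc2ccc(Cl)cc2/C1=C\c1c(Cl)n(CCCc2ccccc2)c2ccccc12` is derived from compound 2 by the same change: chloro in place of hydrogen on an aromatic carbon. The place of the change is described in identical words for both pairs, so the two changes are the same. Since the earlier step was a 4.5-fold higher number from compound 1 to compound 3 (0.65 log units; beyond the scatter), the step from compound 2 to compound 4 is expected to be of similar size, tempered slightly: the expected step is a 3.4-fold higher number from compound 2 to compound 4 (0.53 log units; beyond the scatter). On that basis compound 4 is estimated at 30000 nM in this assay, with a plausible range from 12000 nM to 80000 nM.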

Compound 4, concentration for 50% growth inhibition: 2880 nM
Estimate against measurement, compound 4: 10-fold (1.02 log units) above; measured number below the stated range.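

In this assay, chloro in place of hydrogen on an aromatic carbon gave a 3.1-fold lower number from compound 2 to compound 4 (0.49 log units; beyond the scatter), so on this core the chlorinated compound inhibits growth more strongly, whereas on the core of compound 1 the same change weakened it. The change therefore does not carry over from one core to the other in this series, since its effect reverses in direction and the two steps stand clearly apart: the same change on two cores in this assay, a 4.5-fold higher number (0.65 log units; beyond the scatter) from compound 1 to compound 3 and a 3.1-fold lower number (0.49 log units; beyond the scatter) from compound 2 to compound 4, 14-fold (1.14 log units) apart, beyond the scatter of two such steps. Within the data shown here, with only one pair on each core, this shows that the outcome of the change depends on the core it is placed on, but it does not show which feature of the two cores is responsible, nor how the change would behave on any third core.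

The compounds shown leave open whether another halogen such as fluoro or bromo, or a different kind of group such as an amine, would split between the two cores in the same way when placed on that aromatic carbon. They also leave open whether a shorter chain or a longer chain in place of the phenylpropyl chain of compound 2 would alter the step seen with chloro.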